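A few compounds are considered here, and "the series" means these few. Any claim that something is new, unique, unknown or untested is made for them only; others in the source may bear on it.

Among the compounds with values here, compound 2 `Cc1cc(OCc2nnc(SCc3ccc(Cl)cc3Cl)o2)cc2oc(=O)cc(C)c12` is one of two compounds measured in a functional assay on MCF7 cells (Homo sapiens) for antiproliferative activity, read by MTT assay, with a stated time of 24 h; on this read-out lower numbers stand for stronger inhibition and higher numbers for weaker inhibition. In this assay compound 2 reaches only a limit, < 5000 nM. Compound 1 `CCCCCSc1nnc(COc2cc(C)c3c(C)cc(=O)oc3c2)o1` likewise gives only a limit, > 100000 nM. Within the data shown here, the single measured step, an at least 20-fold lower number from compound 1 to compound 2 (1.30 log units; beyond the scatter), is the only guide available. Compound 3 `Cc1cc(OCc2nnc(S(=O)(=O)Cc3ccccc3)o2)cc2oc(=O)cc(C)c12` differs from compound 2 by benzylsulfonyl in place of (2,4-dichlorobenzyl)sulfanyl on an aromatic carbon. Among the measured compounds shown here, that earlier step bears on this change only loosely, since compound 3 keeps one six-membered aromatic ring of carbon only, while no measured step covers the sulfonyl or the loss of the two chlorines. A step of an at least 1.6-fold higher number from compound 2 to compound 3 (0.20 log units; that floor lies within the scatter) toward weaker inhibition is therefore expected. Compound 3 is estimated at 8000 nM, with a range from 1500 nM to 40000 nM.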

Compound 3, half-maximal inhibitory concentration: 38600 nM
For compound 3 the middle estimate is 4.8-fold (0.68 log units) below the measured one, within the range that was stated.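

Within the data shown here, compound 3 gives the first exact number at this place on the five-membered aromatic ring in this assay, and it shows that changing the group here can move the number either way: an at least 7.7-fold higher number from compound 2 to compound 3 (0.88 log units; beyond the scatter), yet an at least 2.5-fold lower number from compound 1 to compound 3 (0.41 log units; beyond the scatter). The first step is only a floor, set by a limit for compound 2: the limit of < 5000 nM in this assay, at which 1 of the 3 values shown sits. The second is also a floor, set by a limit for compound 1: the limit of > 100000 nM in this assay, at which 1 of the 3 values shown sits.

The compounds shown do not separate the effect of the sulfonyl from that of losing the two chlorines. On these data alone, how an amine or a carboxylic acid at this place would read also stays open.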